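A few compounds are considered here, and "the series" means these few. Any claim that something is new, unique, unknown or untested is made for them only; others in the source may bear on it.

In a functional assay on T47D cells (Homo sapiens) for cytotoxicity, read by MTT assay, with a stated time of 24 h (a higher number here means a weaker inhibitor, a lower number a stronger inhibitor), compound 1 `COc1ccc(/C=C\C(=O)O)c(OCc2cn(-c3ccc(NC(C)=O)cc3)nn2)c1CC=C(C)C` gives 17400 nM. Among the measured compounds shown here, compound 3 `COc1cccc(-n2cc(COc3c(/C=C\C(=O)O)ccc(OC)c3CC=C(C)C)nn2)c1` gives 20400 nM in this assay, the higher of the two numbers on record, although the single step of a 1.2-fold higher number from compound 1 to compound 3 (0.07 log units; within the scatter) lies within the scatter, so the two compounds cannot be ranked against each other. For compound 2 `COc1ccccc1-n1cc(COc2c(/C=C\C(=O)O)ccc(OC)c2CC=C(C)C)nn1` the outcome in this assay reads "not determined" (no result reported), and it adds nothing to the comparison.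

Compound 4 `COc1ccc(/C=C\C(=O)O)c(OCc2cn(-c3cccc(C#N)c3)nn2)c1CC=C(C)C` differs from compound 3 by cyano in place of methoxy on an aromatic carbon, so that 3-methoxyphenyl becomes 3-cyanophenyl. For the measured compounds named here, no measured pair carries this exact exchange. Going by the values given here, the only step that bears on it is a 1.2-fold higher number from compound 1 to compound 3 (0.07 log units; within the scatter), which replaces one substituent on the same phenyl ring with another and leaves the number within the scatter. Two different groups on that ring have thus given numbers indistinguishable from each other, which suggests that a third small group there is unlikely to move this assay far, with no direction favoured. Compound 4 is therefore expected to give 20000 nM, with a range from 8000 nM to 50000 nM, and the expected step of a 1.0-fold lower number from compound 3 to compound 4 (0.01 log units; within the scatter) is estimated to stay within the scatter.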

Compound 4, half-maximal inhibitory concentration: 19200 nM
For compound 4 the middle estimate is 1.0-fold (0.02 log units) above the measured one; low and high end bracket the measured number.
By their numbers in this assay, from the lowest: compounds 1, 4 and 3 (each within the scatter of the next).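

In this assay, among the compounds shown here, the exchange of methoxy for cyano on the aromatic carbon gives a 1.1-fold lower number from compound 3 to compound 4 (0.03 log units; within the scatter) and so provides a direct reading of this change on the same ring position, which the earlier compounds could not give. The step of a 1.1-fold higher number from compound 1 to compound 4 (0.04 log units; within the scatter) adds that 3-cyanophenyl cannot be told apart from 4-acetamidophenyl either, so the three aryl groups in compound 1, compound 3 and compound 4 all give numbers within the scatter of one another, and this assay does not separate them. No measurement at hand accounts for this lack of separation.

Going by these compounds, it remains open whether a group of another kind on this phenyl ring, such as an amine, a carboxylic acid or a longer alkyl chain, would also leave the number within the scatter. Compound 1, compound 3 and compound 4 also share the same core, so they say nothing about how a change there, such as a methyl ester in place of its carboxylic acid, would act in this assay.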